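Dimethylamino for acetyl on a shared pyrazole-free described core

The source may hold more compounds than are shown below. What is called first, only, known or untested is meant among the compounds shown, and "the series" means these compounds.

Compound 1 `COc1cc(C)cc(-c2c(-c3ccnc(-c4ccc(C(C)=O)cc4)c3)cnn2CC#N)c1` was tested in a functional assay on RXF 393 cells (Homo sapiens) for cytotoxicity, read by sulforhodamine B assay, with a stated time of 48 h, tested at 0.01 uM (on this read-out lower numbers stand for a stronger effect and higher numbers for a weaker effect at the one concentration tested), and gives 101%. Going by the values given here, of the two numbers measured so far, compound 1 has the lower one; compound 2 `COc1cc(C)cc(-c2nn(CC#N)cc2-c2ccnc(-c3ccc(N(C)C)cc3)c2)c1` gives 103% in this assay, and the two values lie within the scatter of each other, so neither can be called stronger or weaker at the one concentration tested. Both numbers sit close to full cell viability.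

Compound 3 `COc1cc(C)cc(-c2c(-c3ccnc(-c4ccc(N(C)C)cc4)c3)cnn2CC#N)c1` differs from compound 1 in one place: dimethylamino in place of acetyl on an aromatic carbon. Among the compounds with values here, no step between measured compounds is available for this change. Compound 2 carries the same dimethylamino group on an otherwise rearranged core and shows no effect beyond the scatter, so no movement beyond the scatter is expected for compound 3 either. Compound 3 is therefore expected to give 102% in this assay, in the range 92% to 112%, which is the expected step of a number 1 percentage points higher from compound 1 to compound 3 (within the scatter).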

Compound 3, a percentage reported as activity, at one concentration (the size of the read-out at that concentration, not a potency): 84%
Compound 3: the middle estimate sits 18 percentage points above what was measured; measured number outside the range, below it.
By their numbers in this assay, from the lowest: compound 3; then compounds 1 and 2 (each within the scatter of the next).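

In this assay the change from 4-acetylphenyl to 4-(dimethylamino)phenyl gives a number 17 percentage points lower from compound 1 to compound 3 (beyond the scatter) and so shows that this position on the shared core can move the read-out at the one concentration tested, which the two earlier numbers alone did not show. The step is modest, but it arises from a swap in which the leaving and entering groups match in heavy-atom count, hydrogen-bond donors and hydrogen-bond acceptors, so those counts do not separate the two compounds. No measurement bearing on the reason for this step is available.

As far as these compounds go, it remains open whether the step is particular to dimethylamino or would also appear with a primary amine, a methoxy group or a carboxylic acid at this position. From the compounds shown here alone, it is also open whether the step would persist at higher concentrations.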